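A few compounds are considered here, and "the series" means these few. Any claim that something is new, unique, unknown or untested is made for them only; others in the source may bear on it.

Among the compounds with values here, compound 3 `Cc1cccc(C(=O)/C=C/c2ccncc2)c1` is one of three compounds measured in a functional assay with Rattus norvegicus as the target (on this read-out lower numbers stand for stronger inhibition and higher numbers for weaker inhibition), where compound 3 gives 39000 nM. Compound 1 `O=C(/C=C/c1ccncc1)c1cccc(C(F)(F)F)c1` gives 41000 nM in this assay, and compound 2 `CC(C)(C)c1ccc(C(=O)/C=C/c2ccncc2)cc1` gives 47000 nM. Compound 3 has the lowest of the three numbers shown, yet all three sit within the usual scatter of one another, so none of them can be called stronger or weaker than the rest. The only step between two of these compounds that differ in one place, methyl in place of trifluoromethyl on an aromatic carbon, runs a 1.1-fold lower number from compound 1 to compound 3 (0.02 log units; within the scatter), a shift too small to count as a real change.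

Compound 4 `O=C(/C=C/c1ccncc1)c1ccccc1` is the next compound. It differs from compound 3 by hydrogen in place of methyl on an aromatic carbon. Within the data shown here, that single measured step is the only guide available: it also concerns a group on an aromatic carbon of the shared core, and it did not move the number beyond the scatter. Taking the methyl away is a smaller alteration still, so no shift beyond the scatter is expected in this assay in either direction. Compound 4 is therefore expected to give 42000 nM, within a range of 20000 nM to 85000 nM. The expected step of a 1.1-fold higher number from compound 3 to compound 4 (0.03 log units; within the scatter) is what that estimate means.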

Compound 4, half-maximal inhibitory concentration: 49000 nM
Estimate against measurement, compound 4: 1.2-fold (0.07 log units) below; the range from low to high includes it.
By their numbers in this assay, from the lowest: compounds 3, 1, 2 and 4 (each within the scatter of the next).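

Compound 4 carries only hydrogen on this aromatic ring, so it gives a bare reference for judging what a group there adds. In this assay, the methyl of compound 3 adds nothing that can be told apart from that reference, as the step of a 1.3-fold higher number from compound 3 to compound 4 (0.10 log units; within the scatter) shows. The two larger groups give the same picture, with a 1.2-fold higher number from compound 1 to compound 4 (0.08 log units; within the scatter) for trifluoromethyl and a 1.0-fold higher number from compound 2 to compound 4 (0.02 log units; within the scatter) for tert-butyl, so hydrogen, methyl, trifluoromethyl and tert-butyl on this ring all leave the number within the scatter, and no measurement offered here gives a reason for that.

As far as these compounds go, all the groups compared so far are hydrogen or small carbon-based groups, so it remains open whether an amine, a carboxylic acid or a hydroxyl group on this ring would move the number beyond the scatter. From the compounds shown here alone, with every change so far confined to this ring, it is also open whether a change elsewhere in the shared core, such as replacing the carbonyl, would produce a real shift in this assay.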